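Adding a second methoxy group to compound 2

A few compounds are considered here, and "the series" means these few. Any claim that something is new, unique, unknown or untested is made for them only; others in the source may bear on it.

The series was tested in an assay on A549 cells for inhibition of transcription factor p65 (Homo sapiens), read by fluorescence, with a stated time of 2 h; on this read-out lower numbers stand for stronger inhibition and higher numbers for weaker inhibition. Compound 1 `COc1ccc(/C=C/C(=O)c2cccc(Br)c2)cc1OC` carries a bromine on one ring and two methoxy groups on the other. In this assay compound 1 reaches only the limit > 50000 nM, not a number. Compound 2 `COc1ccc(/C=C/C(=O)c2cccc(-c3cccc(F)c3)c2)cc1` replaces the bromine with a fluorophenyl group and keeps a single methoxy group. In this assay compound 2 likewise gives only the limit > 50000 nM, not a measured number. Both shown values sit at the same point, as summarised by the limit of > 50000 nM in this assay, at which 2 of the 2 values shown sit, so nothing sets compound 2 apart from compound 1 on the numbers shown. Compound 3 `COc1ccc(/C=C/C(=O)c2cccc(-c3cccc(F)c3)c2)cc1OC` is compound 2 with methoxy in place of hydrogen on an aromatic carbon; the entering group sits ortho to a methoxy group and meta to a large group. Going by the values given here, no measured step from compound 2 is available to anchor the size of this change. With both measured neighbours at the assay limit, the step of a number no higher from compound 2 to compound 3 (the limit leaves the size open) is expected to be none beyond the scatter, and a further limit is the most likely return. Compound 3 is accordingly estimated at 50000 nM in this assay, within 20000 nM to 120000 nM.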

Compound 3, half-maximal inhibitory concentration: 33400 nM
For compound 3 the middle estimate is 1.5-fold (0.18 log units) above the measured one; low and high end bracket the measured number.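

Compound 3 is the only compound shown that returns a number rather than a limit in this assay, which gives this aromatic carbon, ortho to a methoxy group and meta to a large group, its first readable step. Methoxy in place of hydrogen here gives an at least 1.4-fold lower number from compound 2 to compound 3 (0.17 log units; that floor lies within the scatter), and 3-fluorophenyl in place of bromo on the other side of the comparison gives an at least 1.4-fold lower number from compound 1 to compound 3 (0.17 log units; that floor lies within the scatter); both steps start from a limit, so only their floors are known, and neither floor clears the scatter. On the compounds shown, the second methoxy group and the 3-fluorophenyl group occur together only in the compound that leaves the limit, while each compound carrying just one of them stays there: the limit of > 50000 nM in this assay, at which 2 of the 3 values shown sit.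

Going by these compounds, the true size of either step remains open, as does whether either change alone accounts for the move away from the limit. Also open, on these data alone, is how this position responds to anything other than methoxy, such as a hydroxyl group, an ethoxy group, an amine or a carboxylic acid.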